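Isopentyl for 4-methoxyphenoxy on a quinoline core

A few compounds are considered here, and "the series" means these few. Any claim that something is new, unique, unknown or untested is made for them only; others in the source may bear on it.

Measured compounds:
compound 1, `FC(F)(F)c1ccc(-c2ccc3c(NCCCNCc4ccco4)ccnc3c2)cc1`, 237 10^-6 cm/s
compound 2, `COc1ccc(Oc2ccc3c(NCCCNCc4cc(F)ccc4OC)ccnc3c2)cc1`, 317 10^-6 cm/s
compound 3, `COc1ccc(Oc2ccc3c(NCCCNCc4cccc(OC)c4O)ccnc3c2)cc1`, 317 10^-6 cm/s

In an ADME assay for permeability, using PAMPA, with a stated time of 30 min, at pH 7.4 (a lower number here means that the compound crosses the layer more slowly, a higher number that the compound crosses the layer faster), compound 2 gives 317 10^-6 cm/s, and compound 3 gives the same number at the digits shown. Compound 1 gives 237 10^-6 cm/s, a value that lies within the scatter of compound 2, so the three measured compounds cannot be ordered against one another.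

The unmeasured compound 4, `COc1ccc(F)cc1CNCCCNc1ccnc2cc(CCC(C)C)ccc12`, differs from compound 2 in one place: isopentyl in place of 4-methoxyphenoxy on an aromatic carbon. Going by the values given here, only one measured step exists, no change at the digits printed from compound 2 to compound 3 (within the scatter), and it changes the group on the saturated chain carbon, not the aromatic carbon of the fused system that changes here. Among the compounds with values here, no measured pair isolates the change from compound 2 to compound 4. What the data do show is that the two groups at that aromatic carbon in compound 1 and compound 2 gave values within the scatter of each other. On that basis, the step from compound 2 to compound 4 is expected to stay within the scatter, a 1.1-fold lower number from compound 2 to compound 4 (0.04 log units; within the scatter). Compound 4 is therefore estimated at 290 10^-6 cm/s in this assay, with a range from 160 10^-6 cm/s to 500 10^-6 cm/s.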

Compound 4, apparent permeability: 23 10^-6 cm/s
Estimate against measurement, compound 4: 13-fold (1.10 log units) above, outside the stated range (below it).
By their numbers in this assay, from the lowest: compound 4; then compounds 1, 2 and 3 (each within the scatter of the next).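

Putting isopentyl in place of 4-methoxyphenoxy on this aromatic carbon gives a large step in this assay, a 14-fold lower number from compound 2 to compound 4 (1.14 log units; beyond the scatter), the only step beyond the scatter among these compounds. Going by these compounds alone, the one earlier step, no change at the digits printed from compound 2 to compound 3 (within the scatter), lay at a saturated chain carbon and so said nothing about this aromatic carbon, where a single change is now seen to move the number strongly. The change removes an aromatic ring and hydrogen-bond acceptors from this carbon, but nothing available ties the lower number to either feature.

This single pair cannot separate the loss of the ring from the loss of the oxygen atoms. Going by these compounds, whether a cyclohexyl ring or an alkoxy chain at this carbon would stay with compound 2 or fall to compound 4 remains open.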